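Trimming an aromatic ring: from naphthalenyl to phenyl

The source may report more compounds than this note shows. Statements on the series, on what has been measured and on what is new or still open speak of the compounds shown alone.

Compound 1 `Clc1ccc(CO/N=C/c2c(-c3cccc4ccccc34)nc3sccn23)cc1Cl` was tested in an assay on HepG2 cells for agonist activity at nuclear receptor subfamily 1 group I member 3 (Homo sapiens), read by a luciferase reporter, with a stated time of 23 h (a lower number here means that less compound is needed, a higher number that more compound is needed for the effect), and gave 940 nM. Among the measured compounds shown here, of the two compounds measured so far, compound 1 has the higher number; compound 2 `Clc1ccc(-c2nc3occn3c2/C=N/OCc2ccc(Cl)c(Cl)c2)cc1` gives 410 nM in this assay. Compound 3 `Clc1ccc(CO/N=C/c2c(-c3ccccc3)nc3sccn23)cc1Cl` has not yet been measured. It differs from compound 1 in one place: phenyl in place of naphthalen-1-yl on an aromatic carbon. With no comparable change measured here, the expectation is for a step from compound 1 to compound 3 of a 2.1-fold higher number from compound 1 to compound 3 (0.33 log units; beyond the scatter), somewhat weaker, since the smaller group gives away part of what compound 1 carries. Compound 3 is therefore estimated at 2000 nM in this assay, within a range of 700 nM to 6000 nM.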

Compound 3, half-maximal effective concentration: 580 nM
Beside the measured number, compound 3's estimate is 3.4-fold (0.54 log units) above it; the measured number lies below the stated range.
By their numbers in this assay, from the lowest: compounds 2, 3 and 1 (each within the scatter of the next, the first and the last beyond it).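

Replacing naphthalen-1-yl with phenyl on this aromatic carbon gives a 1.6-fold lower number from compound 1 to compound 3 (0.21 log units; within the scatter) in this assay. The second aromatic ring of naphthalen-1-yl is therefore not needed to keep the effect in this assay, and the smaller group serves equally well within the scatter. No measured evidence here bears on this result.

Still open, as far as these compounds go, is how far this position tolerates a change in kind rather than in size, such as a phenyl carrying an amine or a carboxylic acid, or a saturated cyclohexyl ring.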